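This account rests on a few compounds, and the source may have more. Where it says the series, first, only, none or still open, it means among the compounds named here.

Series notes, carbonyl substituent on the shared core. Going by the values given here, compound 1 `Cc1nc(S(C)(=O)=O)ccc1Oc1ncnc(OC2CCN(C(=O)O[C@H](C)CF)CC2)c1F` carries a group of 5 heavy atoms (3 carbon, 1 oxygen, 1 fluorine; no ring) on the carbonyl carbon; in a functional assay on isolated protein for inhibition of Glucose-dependent insulinotropic receptor (Homo sapiens), read by HTRF and cAMP accumulation (on this read-out higher numbers stand for an effect only at larger amounts of compound and lower numbers for an effect already at smaller amounts), compound 1 gives 196 nM, the highest of the three numbers measured so far. Compound 2 `Cc1nc(S(C)(=O)=O)ccc1Oc1ncnc(OC2CCN(C(=O)SC(C)(C)C)CC2)c1F` gives 4.83 nM in this assay, and compound 3 `CCC(F)(F)C(=O)N1CCC(Oc2ncnc(Oc3ccc(S(C)(=O)=O)nc3C)c2F)CC1` gives 17.4 nM. Both measured changes at this carbonyl carbon move the number down by a large margin: a 41-fold lower number from compound 1 to compound 2 (1.61 log units; beyond the scatter) and an 11-fold lower number from compound 1 to compound 3 (1.05 log units; beyond the scatter). Between the two replacements themselves the gap is only modest, a 3.6-fold higher number from compound 2 to compound 3 (0.56 log units; beyond the scatter).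

Compound 4 `Cc1nc(S(C)(=O)=O)ccc1Oc1ncnc(OC2CCN(C(=O)c3noc(C(C)(C)F)n3)CC2)c1F` is the next variation at the same position: a group of 9 heavy atoms (5 carbon, 2 nitrogen, 1 oxygen, 1 fluorine; one five-membered aromatic ring with 3 hetero atoms) in place of a group of 5 heavy atoms (3 carbon, 1 oxygen, 1 fluorine; no ring), on a carbonyl carbon. The entering group is unlike either of the measured replacements, so neither step applies directly; the steps leaving compound 1, a 41-fold lower number from compound 1 to compound 2 (1.61 log units; beyond the scatter) and an 11-fold lower number from compound 1 to compound 3 (1.05 log units; beyond the scatter), bear on it only in that every change made so far at this carbonyl carbon has given a lower number beyond the scatter. A lower number is therefore expected for compound 4, with the step of a 7.8-fold lower number from compound 1 to compound 4 (0.89 log units; beyond the scatter) estimated to land between the two measured ones, with wide uncertainty. The estimate for compound 4 in this assay is 25 nM, range 6 nM to 100 nM.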

Compound 4, half-maximal effective concentration: 14 nM
Compound 4: middle estimate off by 1.8-fold (0.25 log units), on the high side; the measured number falls inside the stated range.
By their numbers in this assay, from the lowest: compound 2; then compounds 4 and 3 (each within the scatter of the next); then compound 1.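

Working from this assay, the carbonyl carbon also accepts a group with a five-membered aromatic ring with 3 hetero atoms, as a 14-fold lower number from compound 1 to compound 4 (1.15 log units; beyond the scatter), so the lower number relative to compound 1 now holds for all three replacements shown, cyclic and open-chain alike, with no compound going against it. Size and ring content alone do not set the number here: a 1.2-fold lower number from compound 3 to compound 4 (0.09 log units; within the scatter), so the group of 9 heavy atoms and the smaller 1,1-difluoropropyl cannot be told apart in this assay despite their different heavy-atom and acceptor counts. Compound 2 keeps the lowest number, with a 2.9-fold higher number from compound 2 to compound 4 (0.46 log units; beyond the scatter), so the ring-bearing group does not match the (tert-butyl)sulfanyl group, and no measurement at hand accounts for any of these differences.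

The compounds shown leave open whether the sulfur or the tert-butyl part goes with the low number of compound 2, which a tert-butoxy group on the carbonyl carbon would test. They also leave open whether the fluorine on the ring substituent of compound 4 matters, which a plain isopropyl in its place would test.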